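Capping the remaining phenol in the silyl series

The source may report more compounds than this note shows. Statements on the series, on what has been measured and on what is new or still open speak of the compounds shown alone.

Compound 1, `CC[Si](CC)(c1ccc(O)cc1)c1ccc(OCC(=O)C(C)(C)C)cc1`, carries one free hydroxy on its core and one ((tert-butyl)carbonyl)methoxy group. In an ADME assay on MDBK cells (Bos taurus) for cytotoxicity (on this read-out higher numbers stand for lower toxicity in this test and lower numbers for higher toxicity in this test), compound 1 gives 46800 nM. Within the data shown here, the only other measured member, compound 2, `Nc1ccc(C2(c3ccc(O)cc3)CCCCC2)cc1`, is built on a different core; in this assay compound 2 gives 42000 nM. Compound 1 thus stands at the upper end of the two numbers shown, but compound 2 lies within the scatter of it, so the two are not told apart and no step between them is counted.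

Compound 3, `CC[Si](CC)(c1ccc(OCC(=O)C(C)(C)C)cc1)c1ccc(OCC(=O)C(C)(C)C)cc1`, is compound 1 with the second phenol capped in the same way: ((tert-butyl)carbonyl)methyl in place of hydrogen on an oxygen on an aromatic ring. Among the measured compounds shown here, no measured pair in the set carries this change, so there is no step to lean on. The expectation is that compound 3 stays close to compound 1, with a step from compound 1 to compound 3 of a 1.3-fold lower number from compound 1 to compound 3 (0.13 log units; within the scatter) in this assay, that is, no step beyond the scatter in either direction. Compound 3 is estimated at 35000 nM, with a likely range of 12000 nM to 90000 nM in this assay.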

Compound 3, half-maximal cytotoxic concentration: > 100000 nM
Compound 3: only a limit was reported; the forecaster's own chance of this, stated with the estimate: 10%; middle value at least 2.8-fold (0.45 log units) from the limit.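

Putting ((tert-butyl)carbonyl)methyl in place of hydrogen on this oxygen gives an at least 2.1-fold higher number from compound 1 to compound 3 (0.32 log units; beyond the scatter) in this assay, the first step beyond the scatter among the compounds shown. On this read-out the step points towards lower toxicity in this test, so with this group on both oxygens of the shared core, the free hydroxy of compound 1 is not required to keep the number high. The step gives only a lower bound on the change, and its true size cannot be read from this pair: the limit of > 100000 nM in this assay, at which 1 of the 3 values shown sits.

This single pair on a single core leaves open whether the step depends on ((tert-butyl)carbonyl)methyl itself or would also appear with a plain methyl, a longer chain ending in a carboxylic acid, or a chain ending in an amine on the same oxygen. It also leaves open whether the same capping on the hydroxy of compound 2 would move the number in the same direction on that different core.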